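Replacing the nitrogen substituent of compound 3

The source may hold more compounds than are shown below. What is called first, only, known or untested is meant among the compounds shown, and "the series" means these compounds.

In a functional assay on SK-OV-3 cells (Homo sapiens) for cytotoxicity, read by spectrophotometry, with a stated time of 72 h (on this read-out lower numbers stand for stronger inhibition and higher numbers for weaker inhibition), compound 3 (`COc1ccc(-n2c(-c3cc(OC)c(OC)c(OC)c3)cccc2=O)cc1O`) gives 1220 nM. Compound 1 (`COc1ccc(-c2cccc(=O)n2-c2cc(OC)c(OC)c(OC)c2)cc1OCc1ccccc1`) at 2310 nM lies within the scatter of that value, so these two cannot be ranked. Compound 2 (`COc1ccc(-n2c(-c3cc(OC)c(OC)c(OC)c3)cccc2=O)cc1OCc1ccccc1`) stands well clear of both at 25500 nM.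

Compound 4 (`COc1cc(-c2cccc(=O)n2-c2cccc(F)c2)cc(OC)c1OC`) differs from compound 3 by 3-fluorophenyl in place of 3-hydroxy-4-methoxyphenyl on an aromatic nitrogen, with 3-fluorophenyl in place of 3-hydroxy-4-methoxyphenyl on an aromatic nitrogen.

Within the data shown here, only one measured step touches the group that leaves: a 21-fold lower number from compound 2 to compound 3 (1.32 log units; beyond the scatter), with hydrogen in place of benzyl on an oxygen on an aromatic ring. That step is large and beyond the scatter, so this assay can respond strongly to a change on this group. Among the measured compounds shown here, it does not measure the loss of the whole group, and no compound tested so far has a nitrogen substituent without oxygen groups. The direction is therefore a judgement: a higher number is expected, by less than the measured step but still beyond the scatter.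

The expected change is a 6.6-fold higher number from compound 3 to compound 4 (0.82 log units; beyond the scatter). For compound 4 the estimate is 8000 nM, with an expected range from 1800 nM to 35000 nM.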

Compound 4, half-maximal inhibitory concentration: 340 nM
Estimate against measurement, compound 4: 24-fold (1.37 log units) above; measured number below the stated range.
By their numbers in this assay, from the lowest: compound 4; then compounds 3 and 1 (each within the scatter of the next); then compound 2.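

In this assay the nitrogen substituent does not need its oxygen groups: 3-fluorophenyl in place of 3-hydroxy-4-methoxyphenyl on the aromatic nitrogen gives a 3.6-fold lower number from compound 3 to compound 4 (0.55 log units; beyond the scatter). The earlier step, a 21-fold lower number from compound 2 to compound 3 (1.32 log units; beyond the scatter), altered only what sits on one oxygen of this substituent, whereas the new step removes the hydroxy and methoxy groups together, and with them the only hydrogen-bond donor of that substituent, with no loss on this read-out. The step changes several features at once and cannot be divided among them, and nothing measured here bears on why the number falls.

On these data alone, it remains open whether the fluorine contributes to the step or whether losing the oxygen groups is enough, a question that a plain phenyl on the same nitrogen would separate. As far as these compounds go, it is also open how much variety this place accepts, which a 3-chlorophenyl or a 3-aminophenyl would begin to show.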